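A few compounds are considered here, and "the series" means these few. Any claim that something is new, unique, unknown or untested is made for them only; others in the source may bear on it.

Of the compounds shown here, two carry numbers so far. Compound 1 `C#CCSc1nc(Nc2ccc(Cl)cc2)c(C#N)c(-c2ccccc2)n1` in a functional assay on B16-F10 cells (Mus musculus) for inhibition, read by MTT assay, with a stated time of 72 h (on this read-out higher numbers stand for weaker inhibition and lower numbers for stronger inhibition), gives 19800 nM. Within the data shown here, compound 2 `N#Cc1c(Nc2ccc(Cl)cc2)nc(SCc2cn(Cc3ccccc3Cl)nn2)nc1-c1ccccc1` in this assay gives 1590 nM, the lowest of the two numbers; its only neighbour, compound 1, sits at a distance beyond the usual scatter, so compound 2 is the stronger inhibitor of the pair. Compound 3 `N#Cc1c(Nc2ccccc2F)nc(SCc2cn(Cc3ccccc3Cl)nn2)nc1-c1ccccc1` has not yet been measured. It differs from compound 2 in one place: 2-fluorophenyl in place of 4-chlorophenyl on a nitrogen on an aromatic ring. Among the measured compounds shown here, no measured pair shows this exchange, so its size cannot be read from an existing step. The expected step of a 1.6-fold higher number from compound 2 to compound 3 (0.20 log units; within the scatter) is small, close to the scatter, with a lean toward a higher number. Compound 3 is accordingly expected to give 2500 nM in this assay, with a range from 800 nM to 8000 nM.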

Compound 3, half-maximal inhibitory concentration: 5230 nM
Compound 3: the middle estimate sits 2.1-fold (0.32 log units) below what was measured; measured number inside the range.
By their numbers in this assay, from the lowest: compound 2; then compound 3; then compound 1.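

In this assay the group on the nitrogen on the aromatic ring is not indifferent: 2-fluorophenyl in place of 4-chlorophenyl brings a 3.3-fold higher number from compound 2 to compound 3 (0.52 log units; beyond the scatter) and thus weaker inhibition. Among these compounds, this is the first one-place comparison, and of these two groups, 4-chlorophenyl gives the stronger inhibition with the rest of the structure held constant. No available evidence bears on what lies behind this step.

The change swaps the halogen and its ring position together, so the compounds shown cannot separate the two contributions; 2-chlorophenyl and 4-fluorophenyl at this nitrogen would do so. From the compounds shown here alone, whether the step carries over to other groups on the triazole-bearing side chain, or to a 4-methoxyphenyl group at this nitrogen, also remains open.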